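This account rests on a few compounds, and the source may have more. Where it says the series, first, only, none or still open, it means among the compounds named here.

Measured in a functional assay on NSCLC cells (Homo sapiens) for cytotoxicity, with a stated time of 48 h; a higher number here means a weaker inhibitor of growth, a lower number a stronger inhibitor of growth:
compound 1, `COc1cc2c(/C=C3/C(=O)Nc4ccc(Cl)cc43)c(Cl)n(Cc3cc(OC)c(OC)c(OC)c3)c2cc1C`, gives 2290 nM
compound 2, `COc1cc2c(/C=C3/C(=O)Nc4cccc(Cl)c43)c(Cl)n(Cc3cc(OC)c(OC)c(OC)c3)c2cc1C`, gives 3240 nM

Compound 1 holds the lower of the two numbers, but the step of a 1.4-fold higher number from compound 1 to compound 2 (0.15 log units; within the scatter) lies within the scatter, so the two compounds cannot be ordered. Compound 3, `COc1ccc2c(c1)/C(=C\c1c(Cl)n(Cc3cc(OC)c(OC)c(OC)c3)c3cc(C)c(OC)cc13)C(=O)N2`, differs from compound 1 by methoxy in place of chloro on an aromatic carbon. Among the measured compounds shown here, no measured step exchanges chloro for methoxy; the only known step, a 1.4-fold higher number from compound 1 to compound 2 (0.15 log units; within the scatter), swaps one chloro-bearing fragment for another and stays within the scatter. Compound 3 is therefore expected to show no step beyond the scatter in this assay, estimated at 2500 nM (range 1000 nM to 6500 nM), a step of a 1.1-fold higher number from compound 1 to compound 3 (0.04 log units; within the scatter).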

Compound 3, concentration for 50% growth inhibition: 20400 nM
Compound 3: middle estimate off by 8.2-fold (0.91 log units), on the low side; measured number above the stated range.
By their numbers in this assay, from the lowest: compounds 1 and 2 (each within the scatter of the next); then compound 3.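

In this assay, methoxy in place of chloro on this aromatic carbon gives an 8.9-fold higher number from compound 1 to compound 3 (0.95 log units; beyond the scatter). Among the compounds shown here, the earlier pair showed no such sensitivity, since a 1.4-fold higher number from compound 1 to compound 2 (0.15 log units; within the scatter) stayed within the scatter, so this is the first sign that the group on this carbon of the shared core matters for growth inhibition. No available evidence accounts for the step. The compounds shown leave open how a methyl, a fluoro or an amine on this carbon would compare with chloro and methoxy. They also leave open whether a longer ether, such as ethoxy, would differ from methoxy here.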